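Notes on compound 3: cyclopropyl in place of pyridin-4-yl

This account rests on a few compounds, and the source may have more. Where it says the series, first, only, none or still open, it means among the compounds named here.

Going by the values given here, compound 2 `CNc1nc(NCc2ccncc2)cc(-c2ccccn2)n1` gives 304 nM in a functional assay on HEK293 cells for agonist activity at G-protein coupled receptor 39 (Mus musculus), read by inositol phosphate accumulation (on this read-out lower numbers stand for an effect already at smaller amounts and higher numbers for an effect only at larger amounts of compound), the highest of the two numbers measured so far; compound 1 `CNc1nc(NCc2ccc(Cl)cc2)cc(-c2ccccn2)n1` gives 3 nM. Among the compounds with values here, the only measured step at this position, a 100-fold higher number from compound 1 to compound 2 (2.01 log units; beyond the scatter), is large. Compound 3 `CNc1nc(NCC2CC2)cc(-c2ccccn2)n1` carries cyclopropyl in place of pyridin-4-yl on a saturated chain carbon bound to a nitrogen on an aromatic ring. Within the data shown here, no measured step covers this exchange; the step from compound 1 to compound 2 only shows that the group at this position can shift the number strongly. A further increase or no change beyond the scatter both seem possible. For compound 3 the expected step is a 2.0-fold higher number from compound 2 to compound 3 (0.30 log units; within the scatter), modest and toward a higher number. For compound 3 the estimate is 600 nM, within 100 nM to 4000 nM.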

Compound 3, half-maximal effective concentration: 115 nM
Beside the measured number, compound 3's estimate is 5.2-fold (0.72 log units) above it, within the range that was stated.
By their numbers in this assay, from the lowest: compound 1; then compound 3; then compound 2.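

The group on the saturated chain carbon need not be aromatic for the number to fall below that of compound 2 in this assay (a 2.6-fold lower number from compound 2 to compound 3 (0.42 log units; beyond the scatter)). Even so, cyclopropyl does not recover the number of the 4-chlorophenyl group (a 38-fold higher number from compound 1 to compound 3 (1.58 log units; beyond the scatter)), so compound 1 remains the lowest of the series. Nothing at hand bears on the origin of either step.

Open, going by these compounds, is where unsubstituted phenyl, cyclohexyl or a longer alkyl chain would fall relative to compound 1 and compound 3. Also open, on these data alone, is whether a methoxy or an amine in place of the chlorine would retain the low number of compound 1.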